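The source may hold more compounds than are shown below. What is called first, only, known or untested is meant among the compounds shown, and "the series" means these compounds.

Compound 1 `COc1cc(-c2nn(-c3cccc(NC(=O)Nc4cccc(C(F)(F)F)c4)c3)cc2-c2ccncc2)ccc1Cl` gives 1380 nM in a functional assay on NCI-H226 cells (Homo sapiens) for inhibition, read by sulforhodamine B assay, with a stated time of 48 h; a higher number here means a weaker inhibitor of growth, a lower number a stronger inhibitor of growth.
Compound 2 `COc1cc(-c2nn(-c3cccc(NC(=O)c4ccc(Cl)c(C(F)(F)F)c4)c3)cc2-c2ccncc2)ccc1Cl` gives 5900 nM in this assay.

Going by the values given here, of the two measured compounds, compound 2 has the higher number, so it is the weaker growth inhibitor of the pair; its only neighbour is compound 1, and the one measured step runs a 4.3-fold higher number from compound 1 to compound 2 (0.63 log units; beyond the scatter). That step replaced the (3-(trifluoromethyl)phenyl)amino group on the carbonyl carbon with 4-chloro-3-(trifluoromethyl)phenyl, which both removed a hydrogen-bond donor and brought in a chlorine. Compound 3 `COc1cc(-c2nn(-c3cccc(NC(=O)Nc4ccc(Cl)c(C(F)(F)F)c4)c3)cc2-c2ccncc2)ccc1Cl` differs from compound 2 in one place: (4-chloro-3-(trifluoromethyl)phenyl)amino in place of 4-chloro-3-(trifluoromethyl)phenyl on a carbonyl carbon. This puts the nitrogen and its hydrogen-bond donor back while keeping the chlorine, so compound 3 shares the amino group on the carbonyl carbon with compound 1 and the chlorine with compound 2. Among the compounds with values here, the single measured step, a 4.3-fold higher number from compound 1 to compound 2 (0.63 log units; beyond the scatter), is the one that bears on this change, and it acted in the direction of a weaker inhibitor; undoing the larger part of it is expected to move the number back down, by roughly a 5.4-fold lower number from compound 2 to compound 3 (0.73 log units; beyond the scatter). Compound 3 is therefore estimated at 1100 nM, with a likely range of 400 nM to 3000 nM.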

Compound 3, concentration for 50% growth inhibition: 1820 nM
Compound 3: middle estimate off by 1.7-fold (0.22 log units), on the low side; the range from low to high includes it.
By their numbers in this assay, from the lowest: compounds 1 and 3 (each within the scatter of the next); then compound 2.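

Putting the nitrogen back on the carbonyl carbon, with the chlorine kept in place, gives a 3.2-fold lower number from compound 2 to compound 3 (0.51 log units; beyond the scatter) in this assay, so this nitrogen can now be looked at apart from the chlorine. The earlier step from the first pair changed both at once, whereas a 1.3-fold higher number from compound 1 to compound 3 (0.12 log units; within the scatter) isolates the chlorine on the aromatic carbon and shows that adding it makes no difference that can be told from the scatter; among these three compounds, the weaker growth inhibition of compound 2 therefore goes with the missing nitrogen and not with the chlorine. Nothing available explains why the nitrogen matters for this read-out.

The compounds shown do not separate the nitrogen atom itself from the amide hydrogen it carries, and a methyl group on that nitrogen, or an oxygen atom in its place, would test that directly. From the compounds shown here alone, at the aromatic carbon only chloro and hydrogen appear, so it remains open whether fluoro, methoxy or a nitrile there would also leave the number unchanged.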